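Adding a chloro group to a phenyl ring

The source may hold more compounds than are shown below. What is called first, only, known or untested is meant among the compounds shown, and "the series" means these compounds.

Compound 1 `S=C(N/N=C\c1ccnc2ccccc12)Nc1cccnc1`: 1100 nM
Compound 2 `S=C(N/N=C\c1ccnc2ccccc12)Nc1ccccc1`: 1380 nM

Both values come from a functional assay on T47D cells (Homo sapiens) for cytotoxicity, read by MTT assay, with a stated time of 48 h; on this read-out higher numbers stand for weaker inhibition and lower numbers for stronger inhibition. Within the data shown here, on these numbers, compound 2 stands level with compound 1, the only other measured compound. Among the measured compounds shown here, the one measured step is a 1.3-fold higher number from compound 1 to compound 2 (0.10 log units; within the scatter). Compound 3 `S=C(N/N=C\c1ccnc2ccccc12)Nc1ccc(Cl)cc1` keeps the structure of compound 2 but carries chloro in place of hydrogen on an aromatic carbon, para to a large group: chloro in place of hydrogen on an aromatic carbon. The measured step swaps pyridin-3-yl for phenyl and adds no chloro, so it bears on this change only indirectly. For the measured compounds named here, with no measured chloro step to draw on, no step beyond the scatter is expected in this assay. The expected change is a 1.3-fold lower number from compound 2 to compound 3 (0.10 log units; within the scatter). Compound 3 is estimated at 1100 nM, with an expected range of 400 nM to 3000 nM.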

Compound 3, half-maximal inhibitory concentration: 1270 nM
Compound 3: middle estimate off by 1.2-fold (0.06 log units), on the low side, within the range that was stated.
By their numbers in this assay, from the lowest: compounds 1, 3 and 2 (each within the scatter of the next).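

In this assay, chloro in place of hydrogen on an aromatic carbon, para to a large group, gives a 1.1-fold lower number from compound 2 to compound 3 (0.04 log units; within the scatter) and so shows that this position of the phenyl ring can carry a chloro group without a step beyond the scatter. Replacing pyridin-3-yl with 4-chlorophenyl on the amide-type nitrogen gives a 1.2-fold higher number from compound 1 to compound 3 (0.06 log units; within the scatter) and so leaves all three aromatic groups shown at this site level with one another in this assay. No measured evidence bears on this flat result.

Three compounds cannot show how far this tolerance extends. As far as these compounds go, it remains open whether an amine, a carboxylic acid or a longer alkyl chain in the place of the chloro group would move the number beyond the scatter.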